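Urea re-entry on the ring nitrogen of compound 3

A few compounds are considered here, and "the series" means these few. Any claim that something is new, unique, unknown or untested is made for them only; others in the source may bear on it.

Within the data shown here, compound 3 `COc1ncc(-c2ccc3nc(NC4CC4)sc3c2)cc1NS(=O)(=O)c1ccc(F)cc1` gives 1330 nM in a functional assay on A549 cells (Homo sapiens) for antiproliferative activity, read by MTT assay, with a stated time of 72 h (on this read-out lower numbers stand for stronger inhibition and higher numbers for weaker inhibition), the highest of the three numbers measured so far. Compound 1 `COc1ncc(-c2ccc3nc(NC(=O)NCCN(C)C)sc3c2)cc1NS(=O)(=O)c1ccc(F)cc1` gives 470 nM and compound 2 `CCN(CC)CCNC(=O)Nc1nc2ccc(-c3cnc(OC)c(NS(=O)(=O)c4ccc(F)cc4)c3)cc2s1` gives 450 nM; the step of a 1.0-fold lower number from compound 1 to compound 2 (0.02 log units; within the scatter) lies within the scatter. The steps of a 2.8-fold higher number from compound 1 to compound 3 (0.45 log units; beyond the scatter) and a 3.0-fold higher number from compound 2 to compound 3 (0.47 log units; beyond the scatter) both run beyond the scatter, so the cyclopropyl on the aromatic nitrogen stands with a weaker number than either carbamoyl chain.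

Compound 4 `COc1ncc(-c2ccc3nc(NC(=O)NC4CC4)sc3c2)cc1NS(=O)(=O)c1ccc(F)cc1` differs from compound 3 by cyclopropylcarbamoyl in place of cyclopropyl on a nitrogen on an aromatic ring. The change restores a carbamoyl group on that nitrogen, now carrying a cyclopropyl rather than a (2-(dimethylamino)ethyl) or (2-(diethylamino)ethyl) chain. The two steps that bear on it, a 2.8-fold higher number from compound 1 to compound 3 (0.45 log units; beyond the scatter) and a 3.0-fold higher number from compound 2 to compound 3 (0.47 log units; beyond the scatter), show that loss of the carbamoyl chain raised the number modestly. Compound 4 reverses only part of that change, since neither the dimethylamino nor the diethylamino chain is returned, so a lower number than compound 3 is expected, by a step smaller than those two. Compound 4 is expected to give 750 nM, within a range of 350 nM to 1600 nM. The expected step from compound 3 is therefore a 1.8-fold lower number from compound 3 to compound 4 (0.25 log units; within the scatter).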

Compound 4, half-maximal inhibitory concentration: 900 nM
Beside the measured number, compound 4's estimate is 1.2-fold (0.08 log units) below it; low and high end bracket the measured number.
By their numbers in this assay, from the lowest: compounds 2, 1, 4 and 3 (each within the scatter of the next, the first and the last beyond it).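

In this assay, a 1.5-fold lower number from compound 3 to compound 4 (0.17 log units; within the scatter) stays within the scatter, so placing a carbonyl between the aromatic nitrogen and the cyclopropyl gives no separable change at this position. On the amide-type nitrogen, a 1.9-fold higher number from compound 1 to compound 4 (0.28 log units; within the scatter) and a 2.0-fold higher number from compound 2 to compound 4 (0.30 log units; within the scatter) also stay within the scatter, which leaves compound 4 unresolved from compound 1, compound 2 and compound 3, even though compound 3 stands apart from compound 1 and compound 2 beyond the scatter. The gap between the ureas with amino chains and compound 3 therefore cannot be assigned to the carbonyl alone or to the 2-(dimethylamino)ethyl and 2-(diethylamino)ethyl chains alone, and nothing available gives a reason for any of these numbers.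

Open, going by these compounds, is whether a urea with a morpholine ring at the end of the ethyl chain, or with a longer chain ending in dimethylamino, would stand apart from compound 4 in this assay beyond the scatter. Also open, on these data alone, is where a plain acetamide on the aromatic nitrogen would fall relative to compound 3 and compound 1, a comparison that would test the carbonyl without the urea's second nitrogen.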